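The compounds below may be only part of what the source reports. "The series", "measured", "known", "first", "only" and "open" are said of these compounds alone.

In a physicochemical assay for solubility, at pH 6.8 (on this read-out higher numbers stand for higher solubility and lower numbers for lower solubility), compound 3 (`CC(C)N1CCN(Cc2ccc(-c3cnc(N)c(C(=O)N[C@H]4CC[C@H](O)CC4)n3)cc2)CC1`) gives 830000 nM. That lies within the usual scatter of compound 1 (`CN(C)Cc1ccc(-c2cnc(N)c(C(=O)NC[C@@](C)(O)C(F)(F)F)n2)cc1`), which gives 510000 nM. Compound 2 (`CCN(CC)Cc1ccc(-c2cnc(N)c(C(=O)NC[C@@](C)(O)C(F)(F)F)n2)cc1`) reads > 1000000 nM, which is a limit of the assay and not a number. That reading is the limit of > 1000000 nM in this assay, at which 1 of the 3 values shown sits.

Compound 4 (`CC(C)N1CCN(Cc2ccc(-c3cnc(N)c(C(=O)NC[C@@](C)(O)C(F)(F)F)n3)cc2)CC1`) differs from compound 3 in one place: 2-hydroxy-2-(trifluoromethyl)propyl in place of 4-hydroxycyclohexyl on an amide-type nitrogen. In short, 2-hydroxy-2-(trifluoromethyl)propyl comes in place of 4-hydroxycyclohexyl on an amide-type nitrogen.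

Going by the values given here, no measured step covers this change. Among the compounds with values here, the only measured step, an at least 1.9-fold higher number from compound 1 to compound 2 (0.29 log units; that floor lies within the scatter), puts diethylamino in place of dimethylamino, which is a different change in a different place. The closest guide is compound 1, which already carries the entering group and shows 510000 nM, within the scatter of compound 3. No change beyond the scatter is therefore expected, and the estimated step is a 1.0-fold lower number from compound 3 to compound 4 (0.02 log units; within the scatter). The estimate for compound 4 is 800000 nM, with an expected range of 350000 nM to 1000000 nM.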

Compound 4, solubility: > 1000000 nM
Compound 4 ended at the assay's limit (the forecaster's own chance of this, stated with the estimate: 25%); at least 1.2-fold (0.09 log units) between middle value and limit.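

In this assay, compound 4 gives > 1000000 nM, which is a limit of the assay and not a number. Going by these compounds alone, this supplies the only measured step at the amide-type nitrogen, an at least 1.2-fold higher number from compound 3 to compound 4 (0.08 log units; that floor lies within the scatter), while the change on the saturated chain carbon gives an at least 1.9-fold higher number from compound 1 to compound 4 (0.29 log units; that floor lies within the scatter), so neither step can be called a real change. The two limits leave the step from compound 2 to compound 4 unreadable, and any larger difference among these compounds would stay hidden as well: the limit of > 1000000 nM in this assay, at which 2 of the 4 values shown sit.

As far as these compounds go, the true size of both readable steps remains open, since only their floors are known. Also open, from the compounds shown here alone, is how a plain cyclohexyl group or a longer chain without a hydroxyl would read on the amide-type nitrogen, and whether a carboxylic acid there would give a reading clear of the limit.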